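Amide aryl replacement on the shared core: compound 4

A few compounds are considered here, and "the series" means these few. Any claim that something is new, unique, unknown or untested is made for them only; others in the source may bear on it.

Going by the values given here, compound 1 `COc1ccccc1C(=O)Nc1cccc(-c2oc3cc(-c4ccc(F)cc4)ccc3c(=O)c2O)c1` carries the highest number of the three measured so far: in a functional assay on HCC1937 cells (Homo sapiens) for antiproliferative activity, read by CCK-8 assay, with a stated time of 72 h (a lower number here means a stronger inhibitor, a higher number a weaker inhibitor), compound 1 gives 9050 nM. Compound 2 `Cc1cc(C)cc(C(=O)Nc2cccc(-c3oc4cc(-c5ccc(F)cc5)ccc4c(=O)c3O)c2)c1` gives 4860 nM and compound 3 `O=C(Nc1cccc(-c2oc3cc(-c4ccc(F)cc4)ccc3c(=O)c2O)c1)c1cc(F)cc(F)c1` gives 2070 nM, so that a 1.9-fold lower number from compound 1 to compound 2 (0.27 log units; within the scatter), a 4.4-fold lower number from compound 1 to compound 3 (0.64 log units; beyond the scatter) and a 2.3-fold lower number from compound 2 to compound 3 (0.37 log units; beyond the scatter). Compound 4 `O=C(Nc1cccc(-c2oc3cc(-c4ccc(F)cc4)ccc3c(=O)c2O)c1)c1ccc([N+](=O)[O-])cc1` differs from compound 1 in one place: 4-nitrophenyl in place of 2-methoxyphenyl on a carbonyl carbon. Among the compounds with values here, no measured step exchanges these same groups; the two steps that leave compound 1 both lower the number, one within and one beyond the scatter, and both replace the 2-methoxyphenyl with a differently substituted ring. A modest lowering is therefore expected for compound 4, a 2.3-fold lower number from compound 1 to compound 4 (0.35 log units; beyond the scatter). The estimate for compound 4 is 4000 nM, with a range from 1500 nM to 12000 nM.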

Compound 4, half-maximal inhibitory concentration: 5640 nM
Beside the measured number, compound 4's estimate is 1.4-fold (0.15 log units) below it, and the stated range covers the measured number.
By their numbers in this assay, from the lowest: compound 3; then compounds 2, 4 and 1 (each within the scatter of the next).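

With 4-nitrophenyl on the carbonyl carbon, the series shows a 1.6-fold lower number from compound 1 to compound 4 (0.21 log units; within the scatter) and also a 1.2-fold higher number from compound 2 to compound 4 (0.06 log units; within the scatter) so this ring does not separate from 2-methoxyphenyl or 3,5-dimethylphenyl. Only 3,5-difluorophenyl stands apart from it, with a 2.7-fold higher number from compound 3 to compound 4 (0.44 log units; beyond the scatter) so changing the ring at this position does not always leave the number within the scatter. No measurement at hand accounts for that gap.

Open, as far as these compounds go, is whether an amine or a carboxylic acid on this ring, or a longer chain in its place, would bring the number below that of compound 3.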